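Benzyl to tert-butyl on the double-bonded nitrogen: series notes

A few compounds are considered here, and "the series" means these few. Any claim that something is new, unique, unknown or untested is made for them only; others in the source may bear on it.

Values in a functional assay on MDA-MB-231 cells (Homo sapiens) for inhibition, read by MTT assay, with a stated time of 24 h; on this read-out higher numbers stand for weaker inhibition and lower numbers for stronger inhibition:
compound 1 `[O-]/[N+](=C\c1cn(-c2ccc(C(F)(F)F)cc2)nn1)Cc1ccccc1`: > 100000 nM, a limit of the assay
compound 2 `CCCCCCCCn1cc(/C=[N+](\[O-])Cc2ccccc2)nn1`: > 100000 nM, a limit of the assay
compound 3 `CC(C)(C)/[N+]([O-])=C/c1cn(-c2ccc(C(F)(F)F)cc2)nn1`: 48200 nM

Compound 1 and compound 2 differ in more than one place; the difference between the two cores is not broken down here. The change tert-butyl in place of benzyl on a double-bonded nitrogen gave an at least 2.0-fold lower number from compound 1 to compound 3 (0.31 log units; beyond the scatter), the size of the step known only as a minimum because of the limit of > 100000 nM in this assay, at which 2 of the 3 values shown sit. The same change, (tert-butyl in place of benzyl on a double-bonded nitrogen), gives compound 4 `CCCCCCCCn1cc(/C=[N+](\[O-])C(C)(C)C)nn1`, not yet measured in this assay. For compound 4 a step of about an at least 1.8-fold lower number from compound 2 to compound 4 (0.25 log units; that floor lies within the scatter) is expected, resting on the earlier step of an at least 2.0-fold lower number from compound 1 to compound 3 (0.31 log units; beyond the scatter). Compound 4 is therefore estimated at 55000 nM, in the range 20000 nM to 150000 nM, with a real chance that only a limit is reported.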

Compound 4, half-maximal inhibitory concentration: 29700 nM
The estimate for compound 4 lay 1.9-fold (0.27 log units) above the measured number, within the range that was stated.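

In this assay tert-butyl in place of benzyl on a double-bonded nitrogen lowered the number on the core of compound 2 as well (an at least 3.3-fold lower number from compound 2 to compound 4 (0.52 log units; beyond the scatter)). The direction of the change therefore carried over between the two cores in these two pairs, and the steps can be set side by side:
the same change on two cores in this assay, an at least 2.0-fold lower number (0.31 log units; beyond the scatter) from compound 1 to compound 3 and an at least 3.3-fold lower number (0.52 log units; beyond the scatter) from compound 2 to compound 4; the limit leaves it open whether they differ
What this does not show is the true size of either step or whether the change is worth the same on both cores, since each step starts from a limit: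
the limit of > 100000 nM in this assay, at which 2 of the 4 values shown sit.

Open, on these data alone, is how isopropyl or cyclohexyl on the double-bonded nitrogen would compare with tert-butyl. Also open, as far as these compounds go, is whether the step would hold on a core carrying an amine.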